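A few compounds are considered here, and "the series" means these few. Any claim that something is new, unique, unknown or untested is made for them only; others in the source may bear on it.

In a functional assay on LoVo cells (Homo sapiens) for inhibition, read by MTT assay (on this read-out lower numbers stand for stronger inhibition and higher numbers for weaker inhibition), compound 1 `CCCCCCCCCCCC(=O)OC1=C(CC=C(C)C)C(=O)c2ccccc2C1=O` gives 27000 nM and compound 2 `CCCCCCCCCCCCCC(=O)OC1=C(CC=C(C)C)C(=O)c2ccccc2C1=O` gives 50000 nM on the same core. Among the compounds with values here, compound 2 therefore stands within the scatter of compound 1, the only other compound measured so far, and the two numbers cannot be ranked. Compound 3 `CCCCCCCCCCCCCCCC(=O)OC1=C(CC=C(C)C)C(=O)c2ccccc2C1=O` differs from compound 2 by ethyl in place of hydrogen on a saturated chain carbon, ten or more bonds along the chain from a carbonyl carbon and this is ethyl in place of hydrogen on a saturated chain carbon, ten or more bonds along the chain from a carbonyl carbon. Within the data shown here, the one measured step that bears on this is the same change made earlier along the chain, a 1.9-fold higher number from compound 1 to compound 2 (0.27 log units; within the scatter) and it did not leave the scatter. A single step of that size sets no trend, so no step beyond the scatter is expected in this assay for the new change. The expected step is a 1.3-fold higher number from compound 2 to compound 3 (0.11 log units; within the scatter) with only a slight lean toward a higher number. For compound 3 the estimated value is 65000 nM with an expected range of 25000 nM to 170000 nM until the measurement is made.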

Compound 3, half-maximal inhibitory concentration: 29000 nM
Estimate against measurement, compound 3: 2.2-fold (0.35 log units) above, within the range that was stated.
By their numbers in this assay, from the lowest: compounds 1, 3 and 2 (each within the scatter of the next).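

In this assay, the change of ethyl in place of hydrogen on a saturated chain carbon, ten or more bonds along the chain from a carbonyl carbon, has now been read twice, as a 1.9-fold higher number from compound 1 to compound 2 (0.27 log units; within the scatter) and as a 1.7-fold lower number from compound 2 to compound 3 (0.24 log units; within the scatter); both steps lie within the scatter, so no direction can be assigned to this change at this place. The step across the whole span, butyl in place of hydrogen, is a 1.1-fold higher number from compound 1 to compound 3 (0.03 log units; within the scatter), so even the longer group leaves the number within the scatter, and compound 1, compound 2 and compound 3 cannot be ranked against one another. No other measurement bears on this result, and nothing given here accounts for these numbers.

As far as these compounds go, whether a longer chain, or an amine or a carboxylic acid in place of hydrogen on this saturated chain carbon, would bring a step beyond the scatter remains open. Also open, from the compounds shown here alone, is whether a change on the shared core, such as a hydroxyl group in place of the ester, would move the number further than any change to the chain has so far.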